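From 4-methylpiperidin-1-yl to piperidin-1-yl

A few compounds are considered here, and "the series" means these few. Any claim that something is new, unique, unknown or untested is made for them only; others in the source may bear on it.

Measured in a physicochemical assay for solubility, in phosphate buffer, measured as kinetic solubility, at pH 7.4; on this read-out lower numbers stand for lower solubility and higher numbers for higher solubility:
- Compound 1 `Cc1ccccc1-c1nc(CN2CCC(C(=O)NCCCN3CCC(C(C)C)CC3)CC2)c(C)o1`: > 71 ug/mL, a limit
- Compound 2 `Cc1ccccc1-c1nc(CN2CCC(C(=O)NCCCN3CCC(C)CC3)CC2)c(C)o1`: > 67 ug/mL, a limit

Compound 2 has no exact number in this assay, only the limit > 67 ug/mL. Compound 3 `Cc1ccccc1-c1nc(CN2CCC(C(=O)NCCCN3CCCCC3)CC2)c(C)o1` carries hydrogen in place of methyl on a saturated ring carbon. Within the data shown here, the one measured step of this kind, also on a saturated ring carbon, is a step that the two limits leave unreadable from compound 1 to compound 2, so it gives no size to build on. No change beyond the usual scatter is therefore expected, and the estimated step is a step that the limit leaves unreadable from compound 2 to compound 3. Compound 3 is expected at 70 ug/mL. The estimated range for compound 3 runs from 45 ug/mL to 100 ug/mL.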

Compound 3, solubility: > 65 ug/mL
Compound 3: only a limit was reported (the forecaster's own chance of this, stated with the estimate: 80%); the middle value does not contradict the limit.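

Among these compounds, compound 1, compound 2 and compound 3 each carry only a limit in this assay, and no step among them can be read. The compounds shown leave open whether isopropyl, methyl or hydrogen on the saturated ring carbon changes the solubility at all.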